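The compounds below may be only part of what the source reports. "The series", "measured", "known", "first", "only" and "open" are said of these compounds alone.

Compound 1 `COc1ccccc1/C=C/C=C/C(=O)c1ccccc1Cl`: 9.45 ug/mL
Compound 2 `COc1ccccc1/C=C/C=C/C(=O)c1ccc([N+](=O)[O-])cc1`: 13.9 ug/mL
Compound 3 `COc1ccccc1/C=C/C=C/C(=O)c1cc(OC)c(OC)c(OC)c1`: 25.9 ug/mL

In a physicochemical assay for solubility, read by spectrophotometry, with stated times of 1 h and 30 min (a higher number here means a more soluble compound, a lower number a less soluble compound), compound 1 gives 9.45 ug/mL. Compound 2, at 13.9 ug/mL, lies within the usual scatter of compound 1. Compound 3, at 25.9 ug/mL, stands higher than compound 1, and that gap goes beyond the scatter.

Compound 4 `O=C(/C=C/C=C/c1ccccc1)c1ccccc1Cl` has not yet been measured. It departs from compound 1 in one place: hydrogen in place of methoxy on an aromatic carbon. In words, it carries hydrogen in place of methoxy on an aromatic carbon. The three measured compounds differ from one another in more than one place, so they give no direct measure of this change. With no such evidence, no step beyond the scatter is expected in this assay, and the estimate stays close to compound 1 at 9.45 ug/mL. The expected change is small, a 1.1-fold lower number from compound 1 to compound 4 (0.02 log units; within the scatter). For compound 4 the expected value is 9 ug/mL, with an estimated range from 4.5 ug/mL to 18 ug/mL.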

Compound 4, solubility: 8.2 ug/mL
For compound 4 the middle estimate is 1.1-fold (0.04 log units) above the measured one; low and high end bracket the measured number.
By their numbers in this assay, from the lowest: compounds 4, 1, 2 and 3 (each within the scatter of the next, the first and the last beyond it).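

The pair of compound 1 and compound 4 gives the first direct measure of hydrogen in place of methoxy on this aromatic carbon, ortho to a large group: this assay shows a 1.2-fold lower number from compound 1 to compound 4 (0.06 log units; within the scatter). At this place in the core of compound 1, then, the methoxy group can give way to hydrogen without a step beyond the scatter, although this rests on a single pair. Nothing available explains this result or ties it to a measured property of either group.

As far as these compounds go, it remains open whether another group at this place, such as an amine, a carboxylic acid or a longer alkoxy chain, would give a step beyond the scatter. From the compounds shown here alone, it is also open whether hydrogen in place of methoxy would give an equally small step in compound 2 or compound 3, which differ from compound 1 elsewhere.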